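Dichloro for Bromo: Expected Cytotoxicity of Compound 3

This account rests on a few compounds, and the source may have more. Where it says the series, first, only, none or still open, it means among the compounds named here.

Compound 2 `O=C(CCCCC1CCSS1)NCc1cn(CCCOc2ccc3cc(-c4ccc(Br)cc4)c(=O)oc3c2)nn1` stands highest of the two compounds measured in a functional assay on PC-12 cells (Rattus norvegicus) for cytotoxicity, read by MTT assay, with stated times of 3 h and 2 h, tested at 20 uM (a higher number here means a stronger effect of the compound at the concentration tested, a lower number a weaker effect), where compound 2 gives 69.1%, while compound 1 `O=C(CCCCC1CCSS1)NCc1cn(CCCOc2ccc3cc(-c4ccccc4)c(=O)oc3c2)nn1` gives 27.2%. Among the measured compounds shown here, the one recorded step, a number 41.9 percentage points higher from compound 1 to compound 2 (beyond the scatter), concerns the same phenyl group. Compound 3 `O=C(CCCCC1CCSS1)NCc1cn(CCCOc2ccc3cc(-c4ccc(Cl)c(Cl)c4)c(=O)oc3c2)nn1` differs from compound 2 by 3,4-dichlorophenyl in place of 4-bromophenyl on an aromatic carbon. For the measured compounds named here, no measured step covers chloro in place of bromo, so that large halogen step is the only guide, and it argues against a drop. Compound 3 is therefore expected to show a step of a number 0.9 percentage points higher from compound 2 to compound 3 (within the scatter). The estimate for compound 3 in this assay is 70%, between 45% and 90%.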

Compound 3, a percentage reported as activity, at one concentration (the size of the read-out at that concentration, not a potency): 51.2%
For compound 3 the middle estimate is 18.8 percentage points above the measured one; the measured number falls inside the stated range.
By their numbers in this assay, from the lowest: compound 1; then compound 3; then compound 2.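

In this assay, the result shows that the gain at this phenyl group is not confined to 4-bromophenyl: 3,4-dichlorophenyl in place of phenyl gives a number 24 percentage points higher from compound 1 to compound 3 (beyond the scatter) on the same core. The two halogenated groups are not interchangeable, however, with a number 17.9 percentage points lower from compound 2 to compound 3 (beyond the scatter) when 3,4-dichlorophenyl replaces 4-bromophenyl. No evidence is available to explain this difference. The compounds shown leave open whether the change of halogen or the second chlorine accounts for that step. They also leave open how a methoxy group or an amine on this phenyl would compare.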